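A Chloro on the Phenyl Ring of Compound 2

A few compounds are considered here, and "the series" means these few. Any claim that something is new, unique, unknown or untested is made for them only; others in the source may bear on it.

Measured compounds:
compound 1, `COc1ccc(-c2nc(C)c(C(=O)CSc3nc(-c4ccc(OC)c(OC)c4)c(C#N)c(=O)[nH]3)s2)cc1`: 57.6%
compound 2, `COc1ccc(-c2nc(C)c(C(=O)CSc3nc(-c4ccccc4)c(C#N)c(=O)[nH]3)s2)cc1`: 90.9%

Of the compounds shown here, two have been measured in a functional assay on U-87MG ATCC cells for antiproliferative activity against U-87 MG (Homo sapiens), read by MTT assay, with a stated time of 48 h, tested at 10 uM; a higher number here means a weaker effect of the compound at the concentration tested, a lower number a stronger effect. Compound 1 gives 57.6%, and compound 2 gives 90.9%. Within the data shown here, compound 2 thus has the highest of the two numbers; its only neighbour is compound 1, and the step of a number 33.3 percentage points higher from compound 1 to compound 2 (beyond the scatter) is large and beyond the scatter.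

The next compound, compound 3 with structure `COc1ccc(-c2nc(C)c(C(=O)CSc3nc(-c4cccc(Cl)c4)c(C#N)c(=O)[nH]3)s2)cc1`, differs from compound 2 as follows: chloro in place of hydrogen on an aromatic carbon. The group enters on an aromatic carbon of the six-membered ring of carbon only, meta to a large group.

Among the measured compounds shown here, no measured step concerns a chloro entering a phenyl ring; the one known step only shows that changing this ring, from 3,4-dimethoxyphenyl to phenyl, moved the number far. Because the step of a number 33.3 percentage points higher from compound 1 to compound 2 (beyond the scatter) was large, a single chloro on this ring may also move the number, most plausibly downwards, yet its size is uncertain. Compound 3 is therefore estimated at 78%, within 52% to 100%, which means an expected step of a number 12.9 percentage points lower from compound 2 to compound 3 (beyond the scatter).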

Compound 3, a percentage reported as activity, at one concentration (the size of the read-out at that concentration, not a potency): 90.6%
Estimate against measurement, compound 3: 12.6 percentage points below; low and high end bracket the measured number.
By their numbers in this assay, from the lowest: compound 1; then compounds 3 and 2 (each within the scatter of the next).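

In this assay, chloro in place of hydrogen on the phenyl ring, meta to a large group, gives a number 0.3 percentage points lower from compound 2 to compound 3 (within the scatter), so at this position the added chlorine leaves compound 3 indistinguishable from compound 2. The comparison with the dimethoxy compound gives a number 33 percentage points higher from compound 1 to compound 3 (beyond the scatter), a large step like a number 33.3 percentage points higher from compound 1 to compound 2 (beyond the scatter), and so among these three compounds only compound 1, with its 3,4-dimethoxyphenyl group, stands apart, while 3-chlorophenyl stays with phenyl. Nothing measured here bears on why this single chlorine leaves the read-out within the scatter.

As far as these compounds go, it remains open whether a single methoxy group on this ring, or a hydroxy group or an amine in the same place, would bring the number towards that of compound 1. From the compounds shown here alone, it is also open whether chloro elsewhere on the phenyl ring would stay within the scatter of compound 2 as it does here, and which of the two methoxy groups of compound 1 matters for the step to the phenyl and 3-chlorophenyl compounds.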